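The compounds below may be only part of what the source reports. "The series", "measured", "known", "first", "only" and "open" are said of these compounds alone.

Measured compounds:
compound 1 `O=C1C(=O)N(CCCCn2cc(COc3cc(=O)oc4ccccc34)nn2)c2ccccc21`: 85%
compound 2 `O=C1C(=O)N(CCCn2cc(COc3cc(=O)oc4ccccc34)nn2)c2ccccc21`: 93%
compound 3 `O=C1C(=O)N(CCCn2cc(COc3cc(=O)oc4ccccc34)nn2)c2ccc(F)cc21`: 86%

All three values come from a functional assay on THP-1 cells (Homo sapiens) for inhibition, read by sulforhodamine B assay, with a stated time of 48 h, tested at 50 uM; a higher number here means more inhibition of growth at the concentration tested, a lower number less inhibition of growth. Compound 2 and compound 3 differ in one place, (fluoro in place of hydrogen on an aromatic carbon), and this gives a number 7 percentage points lower from compound 2 to compound 3 (within the scatter). The difference between the core of compound 1 and the core of compound 2 is not broken down here; what the two values show is that they lie within the usual scatter of each other. Compound 4 `O=C1C(=O)N(CCCCn2cc(COc3cc(=O)oc4ccccc34)nn2)c2ccc(F)cc21` is not yet measured. Among the measured compounds shown here, it differs from compound 1 by fluoro in place of hydrogen on an aromatic carbon, which is the same change as the one from compound 2 to compound 3, at a place described in the same words. Because a number 7 percentage points lower from compound 2 to compound 3 (within the scatter) stayed within the scatter, the expected step from compound 1 to compound 4 in this assay is a number 5 percentage points lower from compound 1 to compound 4 (within the scatter), likewise small. The value expected for compound 4 in this assay is 80%, with a range from 68% to 92%.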

Compound 4, percent growth inhibition at one concentration: 77%
The estimate for compound 4 lay 3 percentage points above the measured number; the range from low to high includes it.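

In this assay, fluoro in place of hydrogen on an aromatic carbon gives a number 8 percentage points lower from compound 1 to compound 4 (within the scatter), a small step on the core of compound 1. Set beside the earlier step, the change carries across these two cores with no difference in size: the same change on two cores in this assay, a number 7 percentage points lower (within the scatter) from compound 2 to compound 3 and a number 8 percentage points lower (within the scatter) from compound 1 to compound 4, 1 percentage points apart, within the scatter of two such steps. Among the compounds shown here, this shows only that the step stays within the scatter on both cores at the one concentration tested; it does not show a real effect of fluoro on either core, nor that the same would hold on a further core.

The compounds shown leave open what chloro, methoxy or an amine would give at the same aromatic carbon. They also leave open a longer chain in place of the linking chain of compound 1.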